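The compounds below may be only part of what the source reports. "The series", "measured", "known", "first", "only" and "open" are said of these compounds alone.

Measured so far:
Compound 1 `O=C(c1ccc(Cl)cc1)N1CC(c2nc(-c3cccc(F)c3)no2)C1` gives a limit of the assay in an assay on HEK293 cells for negative allosteric modulation of metabotropic glutamate receptor 5 (Homo sapiens), read by FLIPR; on this read-out higher numbers stand for weaker inhibition and lower numbers for stronger inhibition: > 10000 nM.
Compound 2 `CC1CCCCC1C(=O)N1CC(c2nc(-c3cccc(F)c3)no2)C1` gives a limit in this assay: > 10000 nM.
Compound 3 `O=C(c1ccc(F)c(F)c1)N1CC(c2nc(-c3cccc(F)c3)no2)C1` gives a limit in this assay: > 10000 nM.

Compound 3 stands at a limit of the assay: the limit of > 10000 nM in this assay, at which 3 of the 3 values shown sit. The measured steps that touch the group on the carbonyl carbon, a step that the two limits leave unreadable from compound 1 to compound 3, a step that the two limits leave unreadable from compound 2 to compound 3 and a step that the two limits leave unreadable from compound 1 to compound 2, all run between limits and give no readable size and no direction.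

Compound 4 `Cc1ccc(C(=O)N2CC(c3nc(-c4cccc(F)c4)no3)C2)cc1` carries 4-methylphenyl in place of 3,4-difluorophenyl on a carbonyl carbon. No readable step exists on which an expectation of direction could rest. Compound 4 is therefore expected near the limit, at 10000 nM (range 3000 nM to 30000 nM). The expected step of a number no higher from compound 3 to compound 4 (the limit leaves the size open) is estimated as none beyond the scatter.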

Compound 4, half-maximal inhibitory concentration: > 10000 nM
Compound 4 gave a limit, no number (the forecaster's own chance of this, stated with the estimate: 75%); the middle value lies on the limit itself.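

No step can be read for compound 4 against compound 1, compound 2 or compound 3, since all four stand at one limit: the limit of > 10000 nM in this assay, at which 4 of the 4 values shown sit.

In this assay the compounds shown leave open how far each group on the carbonyl carbon lies from that limit.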